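What a triazole side chain might do

A few compounds are considered here, and "the series" means these few. Any claim that something is new, unique, unknown or untested is made for them only; others in the source may bear on it.

In a toxicity assay on L02 cells (Homo sapiens) for cytotoxicity, read by MTT assay, with a stated time of 72 h (a lower number here means a stronger inhibitor, a higher number a weaker inhibitor), compound 1 (`O=C1c2c[n+]([O-])c3ccccc3c2C(=O)c2c1c1ccccc1n2CCN1CCCCC1`) gives 1050 nM and compound 2 (`CN1CCN(CCCCCCn2c3c(c4ccccc42)C(=O)c2c[n+]([O-])c4ccccc4c2C3=O)CC1`) gives 3800 nM as the higher of the two numbers. Compound 3 (`O=C1c2c[n+]([O-])c3ccccc3c2C(=O)c2c1c1ccccc1n2Cc1cn(C[C@@H](O)CO)nn1`) carries 1-(2,3-dihydroxypropyl)-1H-1,2,3-triazol-4-yl in place of 5-(4-methylpiperazin-1-yl)pentyl on a saturated chain carbon bound to an aromatic nitrogen. Going by the values given here, only one measured step bears on this: a 3.6-fold higher number from compound 1 to compound 2 (0.56 log units; beyond the scatter) which also swaps a group on the chain, so a similarly modest rise in this assay is expected, though the direction is uncertain. The expected change is a 2.1-fold higher number from compound 2 to compound 3 (0.32 log units; beyond the scatter) and remains an estimate. For compound 3 the estimated value is 8000 nM with a range from 2500 nM to 30000 nM around it.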

Compound 3, half-maximal inhibitory concentration: 490 nM
Estimate against measurement, compound 3: 16-fold (1.21 log units) above, outside the stated range (below it).
By their numbers in this assay, from the lowest: compound 3; then compound 1; then compound 2.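

In this assay, changes to the side chain on this saturated chain carbon can lower the number as well as raise it: 1-(2,3-dihydroxypropyl)-1H-1,2,3-triazol-4-yl gives a 7.8-fold lower number from compound 2 to compound 3 (0.89 log units; beyond the scatter) and a 2.1-fold lower number from compound 1 to compound 3 (0.33 log units; beyond the scatter). A side chain with no six-membered non-aromatic ring thus gives the lowest number of the three. No evidence is available on what lies behind this shift.

As far as these compounds go, it remains open whether the triazole ring or the dihydroxypropyl part matters more, which a triazole carrying a plain methyl group could help separate. From the compounds shown here alone, the role of the defined stereocentre also remains open.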